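The source may hold more compounds than are shown below. What is called first, only, known or untested is meant among the compounds shown, and "the series" means these compounds.

Measured compounds in a functional assay on CWR22R cells (Homo sapiens) for inhibition, read by MTT assay, with a stated time of 48 h; a higher number here means a weaker inhibitor, a lower number a stronger inhibitor:
compound 1 `COc1ccc2c(C3CC(c4ccncc4)=NO3)c[nH]c2c1` gives 16300 nM
compound 2 `Clc1ccc(Cn2cc(C3CC(c4ccncc4)=NO3)c3ccccc32)cc1` gives 9600 nM

Compound 2 and compound 1 stand within the scatter of each other in this assay; the two numbers do not separate, and neither compound can be called the stronger or weaker inhibitor on these data. Among the compounds with values here, both carry the same substituent on the five-membered ring; they differ at two places at once, so no single step between them can be read.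

Compound 3 `COc1ccc2c(C3CC(c4ccncc4)=NO3)cn(Cc3ccc(Cl)cc3)c2c1` is the next compound. Relative to compound 2 the change is methoxy in place of hydrogen on an aromatic carbon. Within the data shown here, no single-change step is available to anchor the effect of this change in this assay. Among the measured compounds shown here, the only guide is that compound 1, which also carries a methoxy, sits within the scatter of compound 2. The step from compound 2 to compound 3 is therefore expected to be small, a 1.2-fold lower number from compound 2 to compound 3 (0.08 log units; within the scatter), within the scatter in either direction. For compound 3 the value in this assay is estimated at 8000 nM, with a range from 3000 nM to 22000 nM.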

Compound 3, half-maximal inhibitory concentration: 17300 nM
For compound 3 the middle estimate is 2.2-fold (0.33 log units) below the measured one; the measured number falls inside the stated range.
By their numbers in this assay, from the lowest: compounds 2, 1 and 3 (each within the scatter of the next).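

In this assay, within the data shown here, methoxy in place of hydrogen on the aromatic carbon gives a 1.8-fold higher number from compound 2 to compound 3 (0.26 log units; within the scatter), the first single-change reading at this place, and it does not separate the two compounds. With the methoxy kept, 4-chlorobenzyl in place of hydrogen on the aromatic nitrogen gives a 1.1-fold higher number from compound 1 to compound 3 (0.03 log units; within the scatter), so this change does not separate its two compounds either, and all three numbers remain within the scatter of the next. Nothing measured here offers an explanation for either step.

As far as these compounds go, whether a different group on this aromatic carbon, such as a hydroxyl, a fluorine or a dimethylamino group, would move the number beyond the scatter remains open. Also open, from the compounds shown here alone, is whether another group on the nitrogen, such as an unsubstituted benzyl or a longer alkyl chain, would separate from hydrogen.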